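A few compounds are considered here, and "the series" means these few. Any claim that something is new, unique, unknown or untested is made for them only; others in the source may bear on it.

Compound 1 `O=C(Nc1ccc(Sc2nc3ccccc3s2)c(Cl)c1)c1cccc(Br)c1` and compound 3 `O=C(Nc1ccc(Sc2nc3ccccc3s2)cc1)c1cccc(Br)c1` share a core; their cores differ by hydrogen in place of chloro on an aromatic carbon. In an ADME assay on HEK293 cells (Homo sapiens) for cytotoxicity, read by reporter gene assay and resazurin assay, with a stated time of 48 h (on this read-out lower numbers stand for higher toxicity in this test and higher numbers for lower toxicity in this test), compound 1 gives only a limit, > 100000 nM. Compound 3 gives 74000 nM in this assay, a step of an at least 1.3-fold lower number from compound 1 to compound 3 (0.13 log units; that floor lies within the scatter). Compound 2 `O=C(Nc1ccc(Sc2nc3ccccc3s2)c(Cl)c1)c1cc(Br)ccc1O` differs from compound 1 by hydroxy in place of hydrogen on an aromatic carbon, and in this assay compound 2 gives 45000 nM. The step of an at least 2.2-fold lower number from compound 1 to compound 2 (0.34 log units; beyond the scatter) rests on the reading of compound 1, which is a limit: the limit of > 100000 nM in this assay, at which 1 of the 3 values shown sits. Compound 4 `O=C(Nc1ccc(Sc2nc3ccccc3s2)cc1)c1cc(Br)ccc1O` has not yet been measured; it differs from compound 3 by hydroxy in place of hydrogen on an aromatic carbon, the same change, in the same surroundings, as from compound 1 to compound 2. Resting on compound 3 at 74000 nM and on the earlier step of an at least 2.2-fold lower number from compound 1 to compound 2 (0.34 log units; beyond the scatter), the expected step here is a 2.1-fold lower number from compound 3 to compound 4 (0.33 log units; beyond the scatter). Compound 4 is therefore estimated at 35000 nM in this assay.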

Compound 4, half-maximal cytotoxic concentration: 42000 nM
The estimate for compound 4 lay 1.2-fold (0.08 log units) below the measured number; low and high end bracket the measured number.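

On the core of compound 3, the hydroxy change gives a 1.8-fold lower number from compound 3 to compound 4 (0.25 log units; within the scatter) in this assay, so this step alone cannot show that the change has a real effect there, and the comparison with the core of compound 1 gives no firm size for it: the same change on two cores in this assay, an at least 2.2-fold lower number (0.34 log units; beyond the scatter) from compound 1 to compound 2 and a 1.8-fold lower number (0.25 log units; within the scatter) from compound 3 to compound 4; the limit leaves it open whether they differ. The hydrogen-for-chloro change, now read with the hydroxy group present, gives a 1.1-fold lower number from compound 2 to compound 4 (0.03 log units; within the scatter), and it too cannot be said to carry over with the same size: the same change on two cores in this assay, an at least 1.3-fold lower number (0.13 log units; that floor lies within the scatter) from compound 1 to compound 3 and a 1.1-fold lower number (0.03 log units; within the scatter) from compound 2 to compound 4; the limit leaves it open whether they differ. Both comparisons lean on compound 1, which gives only a limit: the limit of > 100000 nM in this assay, at which 1 of the 4 values shown sits.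

Going by these compounds, whether an amine or a carboxylic acid in place of the hydroxy would give a step of similar size stays open. So does whether the hydroxy change would behave alike on cores beyond these two.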